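A few compounds are considered here, and "the series" means these few. Any claim that something is new, unique, unknown or untested is made for them only; others in the source may bear on it.

In a functional assay on MCF7 cells (Homo sapiens) for antiproliferative activity, read by MTT assay, with a stated time of 72 h (on this read-out lower numbers stand for stronger inhibition and higher numbers for weaker inhibition), compound 1 (`O=C(N/N=C/c1ccc(Br)cc1)Nc1ccc(Oc2ccnc3[nH]ccc23)c(F)c1`) gives 930 nM and compound 2 (`O=C(N/N=C/c1ccc(Cl)c(Cl)c1)Nc1ccc(Oc2ccnc3[nH]ccc23)c(F)c1`) gives 998 nM on the same shared core. Among the measured compounds shown here, the two stand level, and the only measured step (a 1.1-fold higher number from compound 1 to compound 2 (0.03 log units; within the scatter)) lies within the scatter. Compound 3 (`O=C(N/N=C/c1ccc(O)cc1)Nc1ccc(Oc2ccnc3[nH]ccc23)c(F)c1`) carries 4-hydroxyphenyl in place of 3,4-dichlorophenyl on a carbon with a double bond to nitrogen. The measured step changed the same place, from 4-bromophenyl to 3,4-dichlorophenyl, and left the number unmoved beyond the scatter. Neither measured compound carries 4-hydroxyphenyl, however, so that step bears on this change only weakly. A modest move toward weaker inhibition in this assay is expected, with little support, and the estimated step (a 1.5-fold higher number from compound 2 to compound 3 (0.18 log units; within the scatter)) starts from compound 2 (998 nM). For compound 3 the estimated value is 1500 nM with an expected range from 450 nM to 5000 nM around it.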

Compound 3, half-maximal inhibitory concentration: "not active" (no number reported)
Nothing numeric was reported for compound 3; no gap can be computed for the estimate.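

Among the compounds shown here, compound 3 is reported as "not active" in this assay, with no number, so no step from compound 2 to compound 3 can be read. No evidence shown bears on this result. The compounds shown leave open where compound 3 stands numerically relative to compound 1 and compound 2.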